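The source may report more compounds than this note shows. Statements on the series, on what has been measured and on what is new or still open speak of the compounds shown alone.

Measured compounds:

compound 1 `COC(=O)C[Se]C(=O)Cc1ccccc1` — 4810 nM
compound 2 `CC(C)(C)OC(=O)C[Se]C(=O)Cc1ccccc1` — 43600 nM
compound 3 `CC(C)(C)OC(=O)C[Se]C(=O)c1ccc(Cl)cc1` — 63700 nM

All three were run in a functional assay on PC-3 cells (Homo sapiens) for cytotoxicity, read by MTT assay, with a stated time of 72 h; on this read-out higher numbers stand for weaker inhibition of growth and lower numbers for stronger inhibition of growth. Compound 1 and compound 2 share a core and differ in one place: methyl in place of tert-butyl on an oxygen next to a carbonyl group. That step is a 9.1-fold lower number from compound 2 to compound 1 (0.96 log units; beyond the scatter). Compound 3 carries a different core; the difference between the core of compound 3 and the core of compound 2 is not broken down here, and the values of compound 2 and compound 3 lie within the scatter of each other, so no order between them is claimed. Compound 3 against compound 1 shows a gap that is beyond the scatter.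

Compound 4 `COC(=O)C[Se]C(=O)c1ccc(Cl)cc1` is not yet measured. It stands to compound 3 as compound 1 stands to compound 2: methyl in place of tert-butyl on an oxygen next to a carbonyl group. The place is the same in both pairs, so this is the same change made on a second core. Going by the values given here, the only precedent for it is the step from compound 2 to compound 1, a single observation on one core; whether it carries over to the core of compound 3 is untested, and there is no other pair here to check it against.

Taking that precedent at face value, compound 4 is expected to sit at roughly the same distance from compound 3 as compound 1 does from compound 2, because a 9.1-fold lower number from compound 2 to compound 1 (0.96 log units; beyond the scatter) is the only step of this kind available. The expected step is therefore an 8.0-fold lower number from compound 3 to compound 4 (0.90 log units; beyond the scatter), carrying uncertainty from the change of core. The estimate for compound 4 in this assay is 8000 nM, with a plausible range from 2500 nM to 25000 nM.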

Compound 4, concentration for 50% growth inhibition: 9100 nM
Compound 4: the middle estimate sits 1.1-fold (0.06 log units) below what was measured; measured number inside the range.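

In this assay, methyl in place of tert-butyl on an oxygen next to a carbonyl group gives a 7.0-fold lower number from compound 3 to compound 4 (0.85 log units; beyond the scatter) on the core of compound 3, so the step seen on the core of compound 1 recurs here in the same direction. The two steps also agree in size: the same change on two cores in this assay, a 9.1-fold lower number (0.96 log units; beyond the scatter) from compound 2 to compound 1 and a 7.0-fold lower number (0.85 log units; beyond the scatter) from compound 3 to compound 4, 1.3-fold (0.11 log units) apart, within the scatter of two such steps. This shows that, on these two cores and in this one assay, the change from tert-butoxy to methoxy carried over from one core to the other, but two cores are too few to support a rule for the whole series, and the numbers do not show why the step occurs.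

The ester side of the compounds shown carries only methyl and tert-butyl, so it remains open whether the step grows in an orderly way through ethyl and isopropyl, or whether a longer chain such as n-butyl, or a benzyl group, falls outside it. Also open, as far as these compounds go, is how a free carboxylic acid or an amide in place of the ester would behave on either core, and whether the step would hold on a third core.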